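A few compounds are considered here, and "the series" means these few. Any claim that something is new, unique, unknown or untested is made for them only; others in the source may bear on it.

Measured so far in an ADME assay on MT4 cells (Homo sapiens) for cytotoxicity, read by MTT assay, with a stated time of 96 h; a lower number here means that less compound is tolerated, a higher number that more compound is tolerated:
compound 1, `COc1ccc(-c2nc3cc(C(C)=O)ccc3[nH]2)c(OC)c1`: 50000 nM
compound 2, `COc1ccc(-c2nc3cc(C(C)=O)ccc3n2C2CCCCC2)c(OC)c1`: 21000 nM
compound 3, `CC(=O)c1ccc2c(c1)nc(-c1ccoc1)n2C1CCCCC1`: 63000 nM

Compound 2 and compound 1 share a core and differ in one place: hydrogen in place of cyclohexyl on an aromatic nitrogen. That change gave a 2.4-fold higher number from compound 2 to compound 1 (0.38 log units; beyond the scatter). Compound 3 carries a different core; the difference between the two cores is not broken down here. Compound 4, `CC(=O)c1ccc2[nH]c(-c3ccoc3)nc2c1`, is the matching analogue of compound 3: hydrogen in place of cyclohexyl on an aromatic nitrogen. The surroundings are not worded alike, since in compound 3 the neighbouring ring atom bears a furan-3-yl group and in compound 2 a large group, so this is the same kind of change rather than the same change. Should it act as before, the step from compound 3 to compound 4 is expected to be a 1.7-fold higher number from compound 3 to compound 4 (0.24 log units; within the scatter), resting on a 2.4-fold higher number from compound 2 to compound 1 (0.38 log units; beyond the scatter). Compound 4 is therefore estimated at 110000 nM, with a range from 55000 nM to 250000 nM. At that level the assay may report only a limit.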

Compound 4, half-maximal cytotoxic concentration: > 100000 nM
Compound 4 gave a limit, no number; the forecaster's own chance of this, stated with the estimate: 40%; the middle value does not contradict the limit.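

In this assay compound 4 gives > 100000 nM, which is a limit of the assay and not a number. Hydrogen in place of cyclohexyl on the aromatic nitrogen gives an at least 1.5-fold higher number from compound 3 to compound 4 (0.20 log units; that floor lies within the scatter), so the floor of this step alone does not establish a change beyond the scatter on this core, though it agrees in direction with the earlier step. The size of the change on the two cores cannot be compared: the same change on two cores in this assay, a 2.4-fold higher number (0.38 log units; beyond the scatter) from compound 2 to compound 1 and an at least 1.5-fold higher number (0.20 log units; that floor lies within the scatter) from compound 3 to compound 4; the limit leaves it open whether they differ

Among the compounds shown here, with only two matched pairs, it remains open whether the change behaves the same way on other cores. Also open, from the compounds shown here alone, is how that aromatic nitrogen responds to other groups, such as a longer chain or a chain ending in an amine.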